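The compounds below may be only part of what the source reports. "The series", "measured", "known", "first", "only" and "open" are said of these compounds alone.

Measured in a functional assay on MCF7 cells (Homo sapiens) for cytotoxicity, read by sulforhodamine B assay, with a stated time of 72 h; a higher number here means a weaker inhibitor, a lower number a stronger inhibitor:
- compound 1 `CCS(=O)(=O)Nc1cc(-c2ccc3ncnc(Nc4ccc(F)cc4F)c3c2)cnc1OC`: 1610 nM
- compound 2 `CCS(=O)(=O)Nc1cc(-c2ccc3ncnc(Nc4ccc(OC(F)(F)F)cc4)c3c2)cnc1OC`: 23700 nM
- compound 3 `CCS(=O)(=O)Nc1cc(-c2ccc3ncnc(Nc4cccc(C(=O)OC)c4)c3c2)cnc1OC`: 10100 nM

Of the three numbers, the middle one belongs to compound 3. On its upper side the data show a 2.3-fold lower number from compound 2 to compound 3 (0.37 log units; beyond the scatter), and on its lower side they show a 6.3-fold higher number from compound 1 to compound 3 (0.80 log units; beyond the scatter).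

Compound 4 `CCS(=O)(=O)Nc1cc(-c2ccc3ncnc(Nc4ccc(Cl)c(C(=O)OC)c4)c3c2)cnc1OC` differs from compound 3 in one place: chloro in place of hydrogen on an aromatic carbon. This is chloro in place of hydrogen on an aromatic carbon, ortho to a methoxycarbonyl group.

Among the measured compounds shown here, no measured step isolates this change. The closest evidence is the exchange of the whole aryl group on the nitrogen, seen in a 15-fold higher number from compound 1 to compound 2 (1.17 log units; beyond the scatter) and in the two steps above. These steps range from modest to large, but each replaces an entire group, so they give only weak guidance on a single added chloro. Compound 1, with its 2,4-difluorophenyl group, has the lowest number at 1610 nM, which gives a slight lean towards a lower number. A small step is therefore expected, and it may well stay within the scatter.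

The expected change is a 1.3-fold lower number from compound 3 to compound 4 (0.13 log units; within the scatter). The estimate for compound 4 is 7500 nM, with an expected range from 2800 nM to 20000 nM.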

Compound 4, half-maximal inhibitory concentration: 1430 nM
Beside the measured number, compound 4's estimate is 5.2-fold (0.72 log units) above it; the whole stated range lies above it.
By their numbers in this assay, from the lowest: compounds 4 and 1 (each within the scatter of the next); then compound 3; then compound 2.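

In this assay, among the compounds shown here, chloro in place of hydrogen on an aromatic carbon, ortho to a methoxycarbonyl group and para to a large group, gives the first step in this set that isolates a single added atom (a 7.1-fold lower number from compound 3 to compound 4 (0.85 log units; beyond the scatter)), showing that this position on the aryl group responds strongly to a one-atom change, more than the earlier whole-group exchanges could indicate. With the chloro in place, the 4-chloro-3-(methoxycarbonyl)phenyl group stands level with the 2,4-difluorophenyl group (a 1.1-fold lower number from compound 1 to compound 4 (0.05 log units; within the scatter)), while it stands well apart from the 4-(trifluoromethoxy)phenyl group (a 17-fold lower number from compound 2 to compound 4 (1.22 log units; beyond the scatter)), so the 3-(methoxycarbonyl)phenyl group no longer sits in the middle of the set. Nothing measured here accounts for the size of the chloro step.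

The compounds shown leave open whether the step belongs to chloro as such, since a bromo, a fluoro or a methyl group at the same carbon would be needed to tell. They also leave open whether the chloro step depends on the methoxycarbonyl group, which a carboxylic acid or a primary amide in its place, or a 4-chlorophenyl group without it, would test.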